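A few compounds are considered here, and "the series" means these few. Any claim that something is new, unique, unknown or untested is made for them only; others in the source may bear on it.

Compound 1 `COc1ccc(S(=O)(=O)N2CCc3cccc(-c4ccc([N+](=O)[O-])cc4)c32)cc1`: 53.1 nM
Compound 2 `COc1ccc(S(=O)(=O)N2CCc3cccc(-c4ccc(F)c(F)c4)c32)cc1`: 46 nM
Compound 3 `COc1ccc(S(=O)(=O)N2CCc3cccc(-c4ccc(F)cc4)c32)cc1`: 95.5 nM

All three values come from a functional assay on NCI-H460 cells (Homo sapiens) for inhibition, with a stated time of 72 h; a lower number here means a stronger inhibitor, a higher number a weaker inhibitor. Compound 3 has the highest number of the three, but only the gap to compound 2 lies beyond the scatter, as a 2.1-fold higher number from compound 2 to compound 3 (0.32 log units; beyond the scatter) shows, and that step is modest. Compound 4 `COc1ccc(-c2cccc3c2N(S(=O)(=O)c2ccc(OC)cc2)CC3)cc1` differs from compound 3 in one group: methoxy in place of fluoro on an aromatic carbon, para to a large group. The closest measured swap at that place is a 1.8-fold higher number from compound 1 to compound 3 (0.25 log units; within the scatter). Among the compounds with values here, no measured compound carries methoxy there. A step beyond the scatter is therefore not expected, and the expected step is a 1.6-fold lower number from compound 3 to compound 4 (0.20 log units; within the scatter). For compound 4 the estimated value is 60 nM, with an expected range of 20 nM to 180 nM.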

Compound 4, half-maximal inhibitory concentration: 302 nM
Estimate against measurement, compound 4: 5.0-fold (0.70 log units) below, outside the stated range (above it).
By their numbers in this assay, from the lowest: compounds 2, 1 and 3 (each within the scatter of the next, the first and the last beyond it); then compound 4.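

In this assay, within the data shown here, methoxy is the first group at this place, para to a large group, to stand clear of all the others: the change gives a 3.2-fold higher number from compound 3 to compound 4 (0.50 log units; beyond the scatter) and, against the other two compounds, a 5.7-fold higher number from compound 1 to compound 4 (0.75 log units; beyond the scatter) and a 6.6-fold higher number from compound 2 to compound 4 (0.82 log units; beyond the scatter). Compound 4 is thus the weakest of the four, and swapping fluoro for methoxy, a hydrogen-bond acceptor by the count, does not leave the number within the scatter. Nothing at hand explains this loss. The compounds shown leave open whether a hydroxyl, an ethoxy or an amine at this place would behave like methoxy.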